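Ester-to-Acid Change and Expected Antiproliferative Potency

The source may report more compounds than this note shows. Statements on the series, on what has been measured and on what is new or still open speak of the compounds shown alone.

Measured compounds:
Compound 1, `CCn1c(C(=O)NCCC(=O)OC)ccc1C(CC)(CC)c1ccc(C#CC(O)(CC)CC)c(C)c1`, 36300 nM
Compound 2, `CCn1c(C(=O)NCC(=O)O)ccc1C(CC)(CC)c1ccc(C#CC(O)(CC)CC)c(C)c1`, 2250 nM
Compound 3, `CCn1cc(C(CC)(CC)c2ccc(C#CC(O)(CC)CC)c(C)c2)cc1C(=O)NCC(=O)OC`, 17500 nM

Of the compounds shown here, three have been measured in a functional assay on PC-3 cells (Homo sapiens) for antiproliferative activity, read by MTT assay, with a stated time of 72 h; on this read-out lower numbers stand for stronger inhibition and higher numbers for weaker inhibition. Compound 1 gives 36300 nM, compound 2 gives 2250 nM, and compound 3 gives 17500 nM. Compound 3 therefore stands second highest of the three numbers in this assay: compound 1 is its nearest neighbour, while compound 2 sits well below it.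

Compound 4, `CCn1cc(C(CC)(CC)c2ccc(C#CC(O)(CC)CC)c(C)c2)cc1C(=O)N[C@@H](C(=O)O)C(C)C`, has not yet been measured. It differs from compound 3 in one place: 1-carboxy-2-methylpropyl in place of (methoxycarbonyl)methyl on an amide-type nitrogen.

Within the data shown here, only one measured step bears on this change. Among the measured compounds shown here, the step of a 16-fold lower number from compound 1 to compound 2 (1.21 log units; beyond the scatter) also replaced an ester-bearing group on the amide-type nitrogen with a carboxy-bearing one, though there the chain was also shortened, and it is the single largest step among the measured compounds. Because of a 16-fold lower number from compound 1 to compound 2 (1.21 log units; beyond the scatter), a clearly lower number in this assay is expected for compound 4 when the (methoxycarbonyl)methyl of compound 3 becomes 1-carboxy-2-methylpropyl. For the measured compounds named here, with only one supporting step, the added branching of the entering group leaves the size uncertain.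

Compound 4 is therefore estimated to reach 2000 nM, within a range of 600 nM to 6500 nM. That estimate corresponds to an expected step of an 8.8-fold lower number from compound 3 to compound 4 (0.94 log units; beyond the scatter).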

Compound 4, half-maximal inhibitory concentration: 10300 nM
The estimate for compound 4 lay 5.2-fold (0.71 log units) below the measured number; measured number outside the range, above it.
By their numbers in this assay, from the lowest: compound 2; then compounds 4 and 3 (each within the scatter of the next); then compound 1.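

In this assay, replacing (methoxycarbonyl)methyl with 1-carboxy-2-methylpropyl on this amide-type nitrogen gives a 1.7-fold lower number from compound 3 to compound 4 (0.23 log units; within the scatter), so this change separates compound 3 and compound 4 by no more than repeated measurements would. The large step seen earlier, a 16-fold lower number from compound 1 to compound 2 (1.21 log units; beyond the scatter), therefore does not carry over to this change: an ester-to-acid exchange on the amide-type nitrogen was followed by a step beyond the scatter in one pair of compounds and by one within it in the other, and the entering groups in those two pairs are not the same. Nothing measured here accounts for the difference between these two outcomes.

As far as these compounds go, the change from compound 3 to compound 4 brings in the carboxy group, the branched chain and a defined stereocentre together, so their separate contributions stay open; a carboxymethyl group or a 1-(methoxycarbonyl)-2-methylpropyl group on the same nitrogen would pull them apart. Also open, from the compounds shown here alone, is how the opposite stereoisomer of the 1-carboxy-2-methylpropyl group, or a chain ending in an amine instead of a carboxylic acid, would read in this assay.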